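Trimming a Side Chain Down to an Amino Group

The compounds below may be only part of what the source reports. "The series", "measured", "known", "first", "only" and "open" are said of these compounds alone.

Of the compounds shown here, two from one series have been tested in an ADME assay on HEp-2 cells (Homo sapiens) for cytotoxicity; on this read-out higher numbers stand for lower toxicity in this test and lower numbers for higher toxicity in this test. Compound 1 `CC(C)CCn1c(Cn2c(=O)n(C(C)C)c3ccccc32)nc2cc(CNC3CC3)ccc21` gives 17200 nM in this assay, and compound 2 `CC(C)CCn1c(Cn2c(=O)n(C(C)C)c3ccccc32)nc2ccc(C#N)cc21` gives 10000 nM in this assay; these two numbers lie within the usual scatter of each other, so no real gap separates them. Compound 3 `CC(C)CCn1c(Cn2c(=O)n(C(C)C)c3ccccc32)nc2cc(N)ccc21` has not yet been measured. It differs from compound 1 in one place: amino in place of (cyclopropylamino)methyl on an aromatic carbon. Among the measured compounds shown here, no measured pair shows this kind of change, so the step is expected to stay close to the scatter, as a 1.2-fold higher number from compound 1 to compound 3 (0.07 log units; within the scatter). Compound 3 is therefore estimated at 20000 nM, with a range from 8000 nM to 50000 nM.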

Compound 3, half-maximal cytotoxic concentration: 32200 nM
Beside the measured number, compound 3's estimate is 1.6-fold (0.21 log units) below it, within the range that was stated.
By their numbers in this assay, from the lowest: compounds 2, 1 and 3 (each within the scatter of the next, the first and the last beyond it).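

In this assay, amino in place of (cyclopropylamino)methyl on this aromatic carbon gives a 1.9-fold higher number from compound 1 to compound 3 (0.27 log units; within the scatter). The side chain can therefore shrink to a single nitrogen and lose its three-membered ring with no real shift in the read-out, at least for this one pair. No measurement here accounts for this outcome.

On these data alone, whether a carboxylic acid or a longer chain of carbon atoms at this position would also stay within the scatter remains open. So does whether a larger amine would.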